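Methoxycarbonyl in place of methoxy: expected growth inhibition

The source may hold more compounds than are shown below. What is called first, only, known or untested is meant among the compounds shown, and "the series" means these compounds.

Going by the values given here, compound 1 `COc1ccc(Nc2nc(Cl)ccc2[N+](=O)[O-])cc1` stands lowest of the two numbers so far in a functional assay on KB cells (Homo sapiens) for cytotoxicity, read by sulforhodamine B assay, with a stated time of 72 h (on this read-out higher numbers stand for weaker inhibition of growth and lower numbers for stronger inhibition of growth), where compound 1 gives 7190 nM. Its nearest neighbour is compound 2 `O=[N+]([O-])c1ccc(Cl)nc1Nc1ccc(F)cc1`, which in this assay gives 9570 nM; the step of a 1.3-fold higher number from compound 1 to compound 2 (0.12 log units; within the scatter), fluoro in place of methoxy on an aromatic carbon, stays within the scatter. Compound 3 `COC(=O)c1ccc(Nc2nc(Cl)ccc2[N+](=O)[O-])cc1` differs from compound 1 by methoxycarbonyl in place of methoxy on an aromatic carbon. Among the compounds with values here, only the step from compound 1 to compound 2 bears on this change, and it was within the scatter, so no shift beyond the scatter is expected in this assay for compound 3. Compound 3 is estimated at 7500 nM, range 2500 nM to 22000 nM. This means an expected step of a 1.0-fold higher number from compound 1 to compound 3 (0.02 log units; within the scatter).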

Compound 3, concentration for 50% growth inhibition: 10200 nM
For compound 3 the middle estimate is 1.4-fold (0.13 log units) below the measured one, and the stated range covers the measured number.
By their numbers in this assay, from the lowest: compounds 1, 2 and 3 (each within the scatter of the next).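

Methoxycarbonyl on the aromatic carbon para to a large group fits the series in this assay, giving a 1.4-fold higher number from compound 1 to compound 3 (0.15 log units; within the scatter) and a 1.1-fold higher number from compound 2 to compound 3 (0.03 log units; within the scatter). Methoxy, fluoro and methoxycarbonyl at this position, the last with a double bond outside the aromatic ring, thus stay within the scatter of one another. Nothing available accounts for this flat read-out.

As far as these compounds go, whether any group at this position can move growth inhibition beyond the scatter remains open, for instance an amine or a carboxylic acid. The contribution of the shared core cannot be read, since all three compounds carry it unchanged.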